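Cytotoxicity in MT2 cells: varying the triazole amide

This account rests on a few compounds, and the source may have more. Where it says the series, first, only, none or still open, it means among the compounds named here.

Measured compounds:
compound 1 `COc1cnc(-c2ccncc2)c2[nH]cc(C(=O)C(=O)N3CCN(C(=O)c4ccccc4)CC3)c12` — 6000 nM
compound 2 `CNC(=O)c1ncn(-c2ncc(OC)c3c(C(=O)C(=O)N4CCN(C(=O)c5ccccc5)CC4)c[nH]c23)n1` — > 300000 nM

In a functional assay on MT2 cells (Homo sapiens) for cytotoxicity, read by XTT assay, with a stated time of 3 days (a higher number here means that more compound is tolerated, a lower number that less compound is tolerated), compound 1 gives 6000 nM. For compound 2 this assay reports only a limit, > 300000 nM, so its true value is not known beyond that, as one of the two values shown sits at the limit of > 300000 nM in this assay, at which 1 of the 2 values shown sits. Among the measured compounds shown here, the single measured step, an at least 50-fold higher number from compound 1 to compound 2 (1.69 log units; beyond the scatter), changes the group on the aromatic carbon and not the amide in question.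

Compound 3 `COc1cnc(-n2cnc(C(=O)N3CCN(C)CC3)n2)c2[nH]cc(C(=O)C(=O)N3CCN(C(=O)c4ccccc4)CC3)c12` differs from compound 2 by 4-methylpiperazin-1-yl in place of methylamino on a carbonyl carbon. No measured step touches this carbonyl carbon, so nothing shown bears directly on the change. With compound 2 already at the limit, compound 3 is expected to stay at or near it, and the step of an at least 1.5-fold lower number from compound 2 to compound 3 (0.17 log units; that floor lies within the scatter) is estimated small. For compound 3 the expected value is 200000 nM, within 50000 nM to 300000 nM.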

Compound 3, half-maximal cytotoxic concentration: > 150000 nM
Compound 3: only a limit was reported; the forecaster's own chance of this, stated with the estimate: 60%; the middle value lies beyond the limit too.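

In this assay compound 3 gives only a limit, > 150000 nM. Compound 2 also gives only a limit, > 300000 nM. With both values limits, the step between compound 2 and compound 3 cannot be read. Left open is whether 4-methylpiperazin-1-yl in place of methylamino on a carbonyl carbon changes the tolerated concentration at all.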